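Adding a second trifluoromethyl to compound 1

The source may report more compounds than this note shows. Statements on the series, on what has been measured and on what is new or still open speak of the compounds shown alone.

In a functional assay on K562 cells (Homo sapiens) for inhibition, read by sulforhodamine B assay, with a stated time of 48 h (a lower number here means a stronger inhibitor of growth, a higher number a weaker inhibitor of growth), compound 1 `O=C(Nc1cccc(-n2cc(-c3ccncc3)c(-c3ccc(Cl)c(O)c3)n2)c1)Nc1cccc(C(F)(F)F)c1` gives > 32500 nM, which is a limit and not a number. Compound 2 `O=C(Nc1cccc(-n2cc(-c3ccncc3)c(-c3ccc(Cl)c(O)c3)n2)c1)Nc1ccc(Cl)c(Cl)c1` gives > 32500 nM, also a limit. Among the measured compounds shown here, the one measured step, a step that the two limits leave unreadable from compound 1 to compound 2, therefore has no readable size, and the limit of > 32500 nM in this assay, at which 2 of the 2 values shown sit, is all that these two compounds offer. Compound 3 `O=C(Nc1cccc(-n2cc(-c3ccncc3)c(-c3ccc(Cl)c(O)c3)n2)c1)Nc1cc(C(F)(F)F)cc(C(F)(F)F)c1` differs from compound 1 by trifluoromethyl in place of hydrogen on an aromatic carbon. Without a readable step, no clear direction can be expected in this assay, and another limit is quite likely. The estimated step is an at least 1.0-fold lower number from compound 1 to compound 3 (0.03 log units; that floor lies within the scatter). For compound 3 the expected value is 30000 nM, with an estimated range of 10000 nM to 40000 nM.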

Compound 3, concentration for total growth inhibition: 3930 nM
The estimate for compound 3 lay 7.6-fold (0.88 log units) above the measured number; measured number outside the range, below it.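

Placing a second trifluoromethyl on this aromatic ring turns an unreadable result into a readable one in this assay, with an at least 8.2-fold lower number from compound 1 to compound 3 (0.91 log units; beyond the scatter). The step starts from a limit, so its printed size is only a floor. Compound 3 alone stands clear of that limit: the limit of > 32500 nM in this assay, at which 2 of the 3 values shown sit.

The compounds shown do not tell whether this gain belongs to trifluoromethyl itself or whether a nitrile or an amine at the same place would give it too. They also leave open whether compound 3 would keep its growth inhibition with only the new trifluoromethyl and hydrogen in place of the original one.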